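The compounds below may be only part of what the source reports. "The series", "measured", "known", "first", "only" and "open" are said of these compounds alone.

In a functional assay on HepG2 cells (Homo sapiens) for inhibition, read by MTT assay, with a stated time of 3 days (on this read-out higher numbers stand for weaker inhibition and lower numbers for stronger inhibition), compound 3 `CCOC(=O)[C@H](NCC(=O)NNC(=O)COc1ccc(-c2nc3ccccc3s2)cc1OC)[C@@H](C)CC` gives 3970 nM, level within the scatter with compound 1 `CC[C@H](C)[C@@H](NCC(=O)NNC(=O)COc1ccc(-c2nc3ccccc3s2)cc1OC)C(=O)O` at 3990 nM and compound 2 `COc1cc(-c2nc3ccccc3s2)ccc1OCC(=O)NNC(=O)CN[C@@H](CS)C(=O)O` at 3120 nM. Compound 4 `CCOC(=O)[C@H](CS(=O)(=O)O)NCC(=O)NNC(=O)COc1ccc(-c2nc3ccccc3s2)cc1OC` carries 1-(ethoxycarbonyl)-2-sulfoethyl in place of 1-(ethoxycarbonyl)-2-methylbutyl on an amine nitrogen.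

For the measured compounds named here, three measured steps bear on this change. Two alter the same substituent on the amine nitrogen: a 1.3-fold lower number from compound 1 to compound 2 (0.11 log units; within the scatter) and a 1.3-fold higher number from compound 2 to compound 3 (0.10 log units; within the scatter). The third, ethyl in place of hydrogen on an oxygen next to a carbonyl group, gives a 1.0-fold lower number from compound 1 to compound 3 (0.00 log units; within the scatter). All three lie within the scatter, so no step beyond the scatter is expected in this assay. Going by the values given here, no measured compound carries the sulfo group, however, so the direction stays open and the range is kept wide. The estimated change is a 1.0-fold higher number from compound 3 to compound 4 (0.00 log units; within the scatter). Compound 4 is expected at 4000 nM, with an estimated range of 1800 nM to 10000 nM.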

Compound 4, half-maximal inhibitory concentration: 3360 nM
Estimate against measurement, compound 4: 1.2-fold (0.08 log units) above; the measured number falls inside the stated range.
By their numbers in this assay, from the lowest: compounds 2, 4, 3 and 1 (each within the scatter of the next).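

At this amine nitrogen the sulfo group, new to the series, leaves the number in this assay level with its neighbours: a 1.2-fold lower number from compound 3 to compound 4 (0.07 log units; within the scatter), with 1-(ethoxycarbonyl)-2-sulfoethyl entering for 1-(ethoxycarbonyl)-2-methylbutyl. The two compounds with a free carboxy substituent give the same picture, with a 1.1-fold higher number from compound 2 to compound 4 (0.03 log units; within the scatter) and a 1.2-fold lower number from compound 1 to compound 4 (0.07 log units; within the scatter), so all of the substituents at this position now shown, sulfo-bearing or not, sit within the scatter of one another. Nothing on hand gives a reason for this flat response at the position.

From the compounds shown here alone, whether any substituent on this nitrogen can move the number beyond the scatter stays open. A side chain ending in an amine, or one carrying a phenyl ring, would test that, and the shared core stays unvaried throughout.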